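The source may hold more compounds than are shown below. What is called first, only, known or untested is meant among the compounds shown, and "the series" means these compounds.

Working notes on the diaryl urea series. In an assay on isolated protein for inhibition of ATP-dependent RNA helicase DDX3X (Homo sapiens), read by FRET, with stated times of 30 s and 40 min (on this read-out lower numbers stand for stronger inhibition and higher numbers for weaker inhibition), compound 1 `O=C(Nc1ccc(-n2cc(CCO[C@H]3O[C@@H](CO)[C@H](O)[C@@H]3O)nn2)cc1)Nc1ccccc1C(F)(F)F` returns "not active" (no number reported) and no number is attached to it. Compound 2 `CCCCc1cn(-c2ccc(NC(=O)Nc3cc(CCC(C)=O)ccc3C)cc2)nn1` gives 2490 nM in this assay. Compound 3 `COCCc1cn(-c2ccc(NC(=O)Nc3ccccc3C)cc2)nn1` gives 1000 nM in this assay, the lowest number among the measured entries; the gap to compound 2 lies beyond the usual scatter, while compound 1 cannot be placed against it.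

Compound 4 `Cc1ccccc1NC(=O)Nc1ccc(-n2cc(CCCN(C)C)nn2)cc1` is not yet measured. It differs from compound 3 by (dimethylamino)methyl in place of methoxy on a saturated chain carbon, two bonds along the chain from an aromatic carbon. Going by the values given here, no pair of measured compounds isolates this change, so the size of the step rests on the structures alone. The dimethylamino chain keeps one hydrogen-bond acceptor and no charge, as does the methoxy it replaces, and the urea and the substituted phenyl ring are held constant. The step from compound 3 to compound 4 in this assay is therefore expected to stay within the scatter, with a slight lean toward a higher number a 1.3-fold higher number from compound 3 to compound 4 (0.11 log units; within the scatter). For compound 4 the estimate in this assay is 1300 nM, with a range from 450 nM to 4000 nM.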

Compound 4, half-maximal inhibitory concentration: 2900 nM
Compound 4: middle estimate off by 2.2-fold (0.35 log units), on the low side; measured number inside the range.
By their numbers in this assay, from the lowest: compound 3; then compounds 2 and 4 (each within the scatter of the next).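

In this assay, (dimethylamino)methyl in place of methoxy on a saturated chain carbon, two bonds along the chain from an aromatic carbon, gives a 2.9-fold higher number from compound 3 to compound 4 (0.46 log units; beyond the scatter). This position therefore responds to the change, although the group that leaves and the group that enters count the same hydrogen-bond donors and acceptors and neither carries a net charge; matching those counts does not hold the number level. No measurement at hand accounts for the step.

The compounds shown leave open whether the higher number follows the amine nitrogen or the added chain length, and a pentyl chain or a 3-methoxypropyl chain on the core of compound 3 would separate the two. As far as these compounds go, how a carboxylic acid in place of the methoxy would read also remains open.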